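Growth inhibition notes: from compound 3 to compound 4

The source may report more compounds than this note shows. Statements on the series, on what has been measured and on what is new or still open speak of the compounds shown alone.

Series so far in an ADME assay on HEK-293T cells (Homo sapiens) for inhibition, read by CCK-8 assay, with a stated time of 48 h, tested at 20 uM (a lower number here means less inhibition of growth, a higher number more inhibition of growth at the concentration tested), as follows:
- compound 1 `N#C/C(=C\c1ccccc1OS(=O)(=O)c1ccc(F)cc1)C(=O)Nc1nnc(Cc2cccc3ccccc23)s1` gives 15% in this series
- compound 2 `Cc1ccc(S(=O)(=O)Oc2ccccc2/C=C(\C#N)C(=O)Nc2nnc(Cc3cccc(F)c3)s2)cc1` gives 9% in this series
- compound 3 `N#C/C(=C\c1ccccc1OS(=O)(=O)c1ccccc1[N+](=O)[O-])C(=O)Nc1nnc(Cc2cccc(F)c2)s1` gives "not toxic" (no number reported) in this series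
- compound 4 `N#C/C(=C\c1ccccc1OS(=O)(=O)c1ccc(F)cc1)C(=O)Nc1nnc(Cc2cccc(F)c2)s1` has not yet been measured

Within the data shown here, compound 3 is recorded as "not toxic" (no number reported) with no figure attached, so it can be placed only in words, and no step starting from it can be calculated. The two numbers available, for compound 1 (15%) and compound 2 (9%), lie within the usual scatter of each other and together mark a single low level.

The step under study is 4-fluorophenyl in place of 2-nitrophenyl on a sulfonyl sulfur and in words puts 4-fluorophenyl in place of 2-nitrophenyl on a sulfonyl sulfur. Among the measured compounds shown here, no measured pair isolates this exchange, so its size cannot be read from the data. No step beyond the scatter is expected in this assay here, and no direction is favoured. For the measured compounds named here, with only three compounds behind it, this expectation is weak, and a report without a number also remains possible. For compound 4 the expected value is 10% within an estimated range of 0% to 25% in this read-out.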

Compound 4, percent growth inhibition at one concentration: 17%
The estimate for compound 4 lay 7 percentage points below the measured number, and the stated range covers the measured number.
By their numbers in this assay, from the lowest: compounds 2, 1 and 4 (each within the scatter of the next).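

In this assay, among these compounds, compound 4 gives 17% and ties both earlier numbers together through single changes: fluoro in place of methyl on an aromatic carbon gives a number 8 percentage points higher from compound 2 to compound 4 (within the scatter) and 3-fluorophenyl in place of naphthalen-1-yl on a saturated chain carbon bound to an aromatic carbon gives a number 2 percentage points higher from compound 1 to compound 4 (within the scatter) without leaving the low level set by the earlier compounds. The exchange of 2-nitrophenyl for 4-fluorophenyl on the sulfonyl sulfur still cannot be read, since compound 3 is recorded only in words and so offers no number to set against compound 4. Nothing at hand explains why these changes leave the read-out at this level.

Open, from the compounds shown here alone, is whether an amine or a carboxylic acid on the phenyl ring of the sulfonyl group would give a number outside this low level. Equally open, going by these compounds, is whether a longer alkyl chain in place of the 3-fluorophenyl group would do so, or whether this level holds in other cell lines and at other concentrations.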